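The source may report more compounds than this note shows. Statements on the series, on what has been measured and on what is new or still open speak of the compounds shown alone.

Compound 1: `COc1cc(NC(C)CCCNC(=O)Nc2ccc(C(F)(F)F)cc2)c2ncccc2c1`, 8400 nM
Compound 2: `COc1cc(NC(C)CCCNC(=O)NNC(=O)Nc2cccc(C(F)(F)F)c2)c2ncccc2c1`, 5600 nM

Both compounds were run in a functional assay on MIA PaCa-2 cells (Homo sapiens) for inhibition, read by MTT assay, with a stated time of 72 h; a higher number here means a weaker inhibitor, a lower number a stronger inhibitor. Compound 2 gives the lowest of the two numbers, but compound 1 sits right beside it, and the gap between them is within the usual scatter of repeated measurements, so on these numbers the two cannot be told apart.

Compound 3 `COc1cc(NC(C)CCCNC(=O)NNC(=O)Nc2ccc(O)cc2)c2ncccc2c1` has not yet been measured in this assay. It is compound 2 with a single change: 4-hydroxyphenyl in place of 3-(trifluoromethyl)phenyl on an amide-type nitrogen. Among the compounds with values here, no pair among the measured compounds shows how this particular swap plays out, so there is nothing in the data to anchor its size. Because compound 2 stands at 5600 nM, the expectation is a modest step toward weaker inhibition, small enough that it may still fall inside the scatter. The two measured compounds lie close together, and that closeness offers no ground for expecting a large step. Compound 3 is therefore estimated at 9000 nM, with a likely range from 3000 nM to 30000 nM. That estimate corresponds to an expected step of a 1.6-fold higher number from compound 2 to compound 3 (0.21 log units; within the scatter).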

Compound 3, half-maximal inhibitory concentration: 142000 nM
Estimate against measurement, compound 3: 16-fold (1.20 log units) below, and the stated range ends below it.
By their numbers in this assay, from the lowest: compounds 2 and 1 (each within the scatter of the next); then compound 3.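

In this assay, putting 4-hydroxyphenyl in place of 3-(trifluoromethyl)phenyl on an amide-type nitrogen gives the first difference in this set that lies beyond the scatter, and it is a large one (a 25-fold higher number from compound 2 to compound 3 (1.40 log units; beyond the scatter)). Compound 1 and compound 2 could not be told apart, yet compound 3 also stands well clear of compound 1 (a 17-fold higher number from compound 1 to compound 3 (1.23 log units; beyond the scatter)), so the group carried on this nitrogen can matter greatly to the read-out, at least for this one swap. No measured property of these groups accompanies the result, and the size of the step stays unexplained.

This single swap removes a trifluoromethyl group, adds a hydroxyl group and changes the ring position of the substituent, and the compounds shown cannot separate these three changes. Plain phenyl, 4-methoxyphenyl or 4-(trifluoromethyl)phenyl in the same place on the compound 2 framework would help show whether the large step follows the loss of trifluoromethyl, the arrival of the hydroxyl group, or the new position on the ring.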